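The compounds below may be only part of what the source reports. "The series", "measured", "known", "first", "only" and "open" are said of these compounds alone.

Notes on the series. Three compounds have numbers in a functional assay on cells (T-cell, Homo sapiens) for inhibition; on this read-out higher numbers stand for weaker inhibition and lower numbers for stronger inhibition. Compound 1 `COc1ccc(-c2cnc3nc(N)nc(N4CCN(C(=O)c5ccccc5)CC4)c3n2)cc1OC` gives 400 nM in this assay, the lowest of the three. Compound 2 `COc1ccc(-c2cnc3nc(N)nc(NCc4cccs4)c3n2)cc1OC` gives 4100 nM, the nearest to compound 1, and the gap between the two lies beyond the scatter. Compound 3 `CCOc1nc(N)nc2ncc(-c3ccc(CC)cc3)nc12` gives 8200 nM, the furthest from compound 1, again beyond the scatter. Among the measured compounds shown here, no two of the measured compounds differ in only one place, so no single step has yet been measured.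

Compound 4 `COc1ccc(-c2cnc3nc(N)nc(N4CCN(Cc5ccccc5)CC4)c3n2)cc1OC` remains to be measured in this assay. It differs from compound 1 as follows: benzyl in place of benzoyl on an amine nitrogen in a ring. For the measured compounds named here, the measured compounds offer no example of a change on an amine nitrogen in a ring, so the direction of this step cannot be read from them; compound 2 and compound 3 differ from compound 1 in more than one place and give no guidance on it. The working expectation for the step of a 1.5-fold higher number from compound 1 to compound 4 (0.18 log units; within the scatter) is that it stays within the scatter, with no direction preferred. Compound 4 is accordingly expected to give about 600 nM in this assay, within a range from 150 nM to 2500 nM.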

Compound 4, half-maximal inhibitory concentration: 900 nM
The estimate for compound 4 lay 1.5-fold (0.18 log units) below the measured number, within the range that was stated.
By their numbers in this assay, from the lowest: compound 1; then compound 4; then compounds 2 and 3 (each within the scatter of the next).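

In this assay, the first change measured on this amine nitrogen in a ring gives a 2.3-fold higher number from compound 1 to compound 4 (0.35 log units; beyond the scatter), a modest step, so benzyl in place of benzoyl at this position moves the number in the direction of weaker inhibition. The change removes the double bond outside aromatic rings and the hydrogen-bond acceptor of benzoyl, while the six-membered aromatic ring of carbon only remains in both compounds, so the step can be tied to the change from benzoyl to benzyl but not to any one of these features. Nothing available explains the size or direction of this step.

On these data alone, the step rests on a single pair on the shared core, and it remains open whether the same change would give a similar step with other substituents on the six-membered aromatic ring of the core. Also open, as far as these compounds go, is how this nitrogen would respond to an acetyl group, a methyl group or a plain hydrogen in place of benzoyl, which would show whether the aromatic ring on this nitrogen matters for the number in this read-out.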